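Cytotoxicity notes on the shared-core ketone series

The compounds below may be only part of what the source reports. "The series", "measured", "known", "first", "only" and "open" are said of these compounds alone.

Measured in an ADME assay on L929 cells (Mus musculus) for cytotoxicity, read by resazurin assay, with a stated time of 72 h; on this read-out higher numbers stand for weaker inhibition and lower numbers for stronger inhibition:
- compound 1 `Cc1ccc(C(=O)c2ccn(-c3ccc4c(c3)B(O)OC4)c2)cc1` gives > 10 ug/mL, a limit of the assay.
- compound 2 `Cc1cccc(C(=O)c2ccn(-c3ccc4c(c3)B(O)OC4)c2)c1` gives > 10 ug/mL, also a limit of the assay.

Compound 2 therefore stands only at a limit in this assay, with no number attached. The step that the two limits leave unreadable from compound 1 to compound 2 cannot be read, since both of its ends sit at the limit of > 10 ug/mL in this assay, at which 2 of the 2 values shown sit.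

Compound 3 `COc1ccc(C(=O)c2ccn(-c3ccc4c(c3)B(O)OC4)c2)cc1` differs from compound 2 by 4-methoxyphenyl in place of 3-methylphenyl on a carbonyl carbon. Going by the values given here, no measured step moves a value off the limit, so the only bearing evidence is the pair of limits at the limit of > 10 ug/mL in this assay, at which 2 of the 2 values shown sit, which gives no direction and no size. For compound 3 in this assay the expected step that the limit leaves unreadable from compound 2 to compound 3 is accordingly none beyond the scatter, with a limit the most likely report. Compound 3 is estimated at 15 ug/mL, between 7 ug/mL and 40 ug/mL.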

Compound 3, half-maximal inhibitory concentration: > 10 ug/mL
Compound 3 gave a limit, no number; the forecaster's own chance of this, stated with the estimate: 85%; the middle value does not contradict the limit.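

In this assay, no step can be read among compound 1, compound 2 and compound 3, as each result is only a limit of the assay: the limit of > 10 ug/mL in this assay, at which 3 of the 3 values shown sit.

The compounds shown leave open whether any group on the carbonyl carbon would give a value inside the readable range.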